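Cytotoxicity notes: from compound 2 toward compound 4

The compounds below may be only part of what the source reports. "The series", "measured", "known", "first", "only" and "open" are said of these compounds alone.

Measured so far:
compound 1 `CC1CN(C(=O)Nc2cc(F)c(F)c(F)c2)Cc2c(N3CC(C#N)CC3=O)cnn21` — 115000 nM
compound 2 `O=C1CC(Oc2ncc(F)cn2)CN1c1cnn2c1CN(C(=O)Nc1cc(F)c(F)c(F)c1)C(C1CC1)C2` — 96200 nM
compound 3 `C[C@H]1Cn2ncc(N3CC(c4ccccc4)CC3=O)c2CN1C(=O)NCc1cc(F)c(F)c(F)c1` — > 2000 nM, a limit of the assay

The read-out throughout is a toxicity assay on HepG2 2.2.15 cells (Homo sapiens) for cytotoxicity, read by CellTiter-Glo; on this read-out higher numbers stand for lower toxicity in this test and lower numbers for higher toxicity in this test. Compound 2 gives 96200 nM in this assay, and compound 1 sits within the scatter of it, so the two cannot be told apart. The value of compound 3 is only a limit (the limit of > 2000 nM in this assay, at which 1 of the 3 values shown sits) and not a number, and it is kept out of any comparison.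

Compound 4 `N#CC1CC(=O)N(c2cnn3c2CN(C(=O)Nc2cc(F)c(F)c(F)c2)C(C2CC2)C3)C1` differs from compound 2 in one place: cyano in place of (5-fluoropyrimidin-2-yl)oxy on a saturated ring carbon. Among the measured compounds shown here, no measured pair isolates this change, so no step size is known for it. Compound 1 carries the same cyano group on that ring and gives 115000 nM in this assay, close to compound 2. On that basis the expected step of a 1.1-fold higher number from compound 2 to compound 4 (0.04 log units; within the scatter) is none beyond the scatter. Compound 4 is estimated at 105000 nM, with a range from 50000 nM to 200000 nM.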

Compound 4, half-maximal cytotoxic concentration: > 200000 nM
Compound 4: no number, only a limit; the forecaster's own chance of this, stated with the estimate: 20%; middle value at least 1.9-fold (0.27 log units) from the limit.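

In this assay, cyano in place of (5-fluoropyrimidin-2-yl)oxy on a saturated ring carbon gives an at least 2.0-fold higher number from compound 2 to compound 4 (0.31 log units; beyond the scatter), so the group at this position does register in the read-out, in the direction of lower toxicity in this test. Among the compounds shown here, the earlier compounds offered no pair differing in one place, which leaves this the only step read at this position. Compound 4 gives only a limit and not a number, so the full size of the step stays unknown: the limit of > 200000 nM in this assay, at which 1 of the 4 values shown sits.

A single pair cannot separate the loss of the (5-fluoropyrimidin-2-yl)oxy group from the entry of the cyano group. On these data alone, how an amine or a carboxylic acid on the same ring carbon would read in this assay also stays open.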